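Adding Methoxy Groups on the Aniline Ring

A few compounds are considered here, and "the series" means these few. Any claim that something is new, unique, unknown or untested is made for them only; others in the source may bear on it.

Of the compounds shown here, two of one shared core have been measured in a functional assay on PC-3 cells (Homo sapiens) for antiproliferative activity, read by MTT assay, with a stated time of 48 h; on this read-out lower numbers stand for stronger inhibition and higher numbers for weaker inhibition. Compound 1 `COc1ccc(-c2nn(-c3ccccc3)cc2C(=O)/C=C\Nc2ccc(F)cc2)cc1` gives 5730 nM in this assay. Among the compounds with values here, compound 2 `COc1ccc(N/C=C\C(=O)c2cn(-c3ccccc3)nc2-c2ccc(OC)cc2)cc1` gives 13400 nM in this assay, the higher of the two numbers, and the only step recorded, a 2.3-fold higher number from compound 1 to compound 2 (0.37 log units; beyond the scatter), arises from a methoxy in place of fluoro on an aromatic carbon.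

Compound 3 `COc1ccc(-c2nn(-c3ccccc3)cc2C(=O)/C=C\Nc2cc(OC)c(OC)c(OC)c2)cc1` has not yet been measured. It differs from compound 2 by 3,4,5-trimethoxyphenyl in place of 4-methoxyphenyl on an amine nitrogen, that is, a 3,4,5-trimethoxyphenyl in place of a 4-methoxyphenyl on the amine nitrogen whose other neighbour is a double-bonded chain carbon. Within the data shown here, the one measured step, a 2.3-fold higher number from compound 1 to compound 2 (0.37 log units; beyond the scatter), alters this same ring and was modest, so it bears on the new change only loosely; no measured pair shows what further methoxy groups on this ring do. Compound 3 is therefore expected to sit near compound 2, with a step of a 1.2-fold lower number from compound 2 to compound 3 (0.09 log units; within the scatter) expected in this assay. The estimate for compound 3 is 11000 nM, within a range of 3500 nM to 35000 nM.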

Compound 3, half-maximal inhibitory concentration: 18900 nM
Beside the measured number, compound 3's estimate is 1.7-fold (0.24 log units) below it; the range from low to high includes it.
By their numbers in this assay, from the lowest: compound 1; then compounds 2 and 3 (each within the scatter of the next).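

In this assay, 3,4,5-trimethoxyphenyl in place of 4-methoxyphenyl on the amine nitrogen gives a 1.4-fold higher number from compound 2 to compound 3 (0.15 log units; within the scatter), so this position tolerates the exchange of one methoxy-bearing ring for the other with no difference that this assay can resolve. The same group in place of 4-fluorophenyl gives a 3.3-fold higher number from compound 1 to compound 3 (0.52 log units; beyond the scatter), a modest step beyond the scatter, so among the three rings shown on this nitrogen, compound 1, with its 4-fluorophenyl, keeps the lowest number, and both methoxy-bearing rings stand apart from it while remaining indistinguishable from each other. The compounds shown offer no evidence bearing on why the numbers fall this way.

These three compounds leave open whether the fluoro group itself sets compound 1 apart, since an unsubstituted phenyl, a chloro group or a hydroxy group on this ring would be needed to separate the effect of fluoro from that of methoxy. They also leave open whether the pattern on the amine nitrogen holds when the rest of the shared core is altered, for instance with a carboxylic acid or a longer chain elsewhere on it.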